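This account rests on a few compounds, and the source may have more. Where it says the series, first, only, none or still open, it means among the compounds named here.

Measured so far in an assay on isolated protein for inhibition of DNA topoisomerase 1 (Homo sapiens), with a stated time of 15 min; a lower number here means a stronger inhibitor, a higher number a weaker inhibitor:
compound 1 `N[C@@H]1CCN(c2cc3c(cc2F)c(=O)c(C(=O)O)cn3Cc2ccc(-c3ccccc3)cc2)C1` — 63600 nM
compound 2 `COc1c(N2CC[C@@H](N)C2)c(F)cc2c(=O)c(C(=O)O)cn(Cc3ccc(-c4ccccc4)cc3)c12` — 92200 nM
compound 3 `O=C(O)c1cn(Cc2ccc(-n3cccn3)cc2)c2cc(NC[C@@H]3CCNC3)c(F)cc2c1=O` — 200000 nM

Compound 1 gives the lowest number of the three. For the measured compounds named here, its nearest neighbour is compound 2, reached by a 1.4-fold higher number from compound 1 to compound 2 (0.16 log units; within the scatter), a step within the scatter; compound 3 lies furthest, beyond the scatter, and differs from compound 1 in several places, so no single step is drawn for that pair.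

Compound 4 `NC[C@@H]1CCN(c2cc3c(cc2F)c(=O)c(C(=O)O)cn3Cc2ccc(-c3ccccc3)cc2)C1` differs from compound 1 by aminomethyl in place of amino on a saturated ring carbon. No measured step covers this change: the one step shown is a methoxy for hydrogen on an aromatic carbon and is itself within the scatter. The series gives no basis for a shift either way, so no step beyond the scatter is expected in this assay; the expected step is a 1.0-fold higher number from compound 1 to compound 4 (0.01 log units; within the scatter). Compound 4 is estimated at 65000 nM, with a range from 25000 nM to 170000 nM.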

Compound 4, half-maximal inhibitory concentration: 15600 nM
Compound 4: the middle estimate sits 4.2-fold (0.62 log units) above what was measured, outside the stated range (below it).
By their numbers in this assay, from the lowest: compound 4; then compounds 1 and 2 (each within the scatter of the next); then compound 3.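

In this assay, for the compounds shown here, aminomethyl in place of amino on a saturated ring carbon gives a 4.1-fold lower number from compound 1 to compound 4 (0.61 log units; beyond the scatter), the first single-change step beyond the scatter. This position therefore responds to a one-carbon extension of the amine-bearing group, with the aminomethyl compound giving the lower number of the pair. No measured evidence accounts for this shift.

Open, going by these compounds, is whether a longer chain such as aminoethyl, or a methylaminomethyl group, extends or reverses the step. Also open, on these data alone, is whether the same change holds on the methoxy-bearing core of compound 2.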